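A six-membered aromatic ring returns at the double-bonded carbon

The source may hold more compounds than are shown below. What is called first, only, known or untested is meant among the compounds shown, and "the series" means these compounds.

In a functional assay on UACC-257 cells (Homo sapiens) for inhibition, read by sulforhodamine B assay, with a stated time of 48 h (on this read-out higher numbers stand for lower toxicity in this test and lower numbers for higher toxicity in this test), compound 1 `NS(=O)(=O)c1ccc(Nc2nc(N/N=C/c3ccc(C(F)(F)F)cc3)nc(Nc3ccccc3)n2)cc1` gives 37200 nM. Compound 2 `Cc1nn(-c2ccccc2)cc1/C=N/Nc1nc(Nc2ccccc2)nc(Nc2ccc(S(N)(=O)=O)cc2)n1` yields only a limit of the measurement, > 100000 nM. Going by the values given here, the single measured step, an at least 2.6-fold higher number from compound 1 to compound 2 (0.42 log units; beyond the scatter), ends at the limit of > 100000 nM in this assay, at which 1 of the 2 values shown sits, so its true size stays unknown. Compound 3 `NS(=O)(=O)c1ccc(Nc2nc(N/N=C/c3ccccn3)nc(Nc3ccccc3)n2)cc1` differs from compound 2 by pyridin-2-yl in place of 3-methyl-1-phenyl-1H-pyrazol-4-yl on a carbon with a double bond to nitrogen. A six-membered aromatic ring thereby comes back at this position, as in compound 1, so compound 3 is expected to move back toward the value of compound 1, 37200 nM. Compound 3 is estimated at 50000 nM, between 18000 nM and 150000 nM, an expected at least 2.0-fold lower number from compound 2 to compound 3 (0.30 log units; that floor lies within the scatter).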

Compound 3, concentration lethal to 50% of the cells: > 100000 nM
Compound 3 was reported as a limit; the forecaster's own chance of this, stated with the estimate: 35%; middle value at least 2.0-fold (0.30 log units) from the limit.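

In this assay, the six-membered aromatic ring of pyridin-2-yl does not bring back the behaviour of compound 1, with an at least 2.6-fold higher number from compound 1 to compound 3 (0.42 log units; beyond the scatter). So a six-membered aromatic ring on this carbon is not enough on its own to give a measurable lethal concentration. Compound 2 and compound 3 both stand at a limit, and the step between them cannot be read: the limit of > 100000 nM in this assay, at which 2 of the 3 values shown sit.

Going by these compounds, how far either compound lies past that limit stays open. Also open, on these data alone, is what separates compound 1 from compound 3, the trifluoromethyl group or the ring nitrogen, which a plain phenyl group on this carbon could help to settle.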